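A chloro to bromo step at an assay limit

The compounds below may be only part of what the source reports. "The series", "measured", "known", "first", "only" and "open" are said of these compounds alone.

Compound 1 `O=C(Nc1ccc(Nc2ncnc3c2OCCN3)cc1)Nc1ccc(Cl)c(C(F)(F)F)c1`: > 10000 nM
Compound 2 `O=C(Nc1ccc(Cl)cc1)Nc1ccc(Nc2ncnc3c2OCCN3)cc1`: > 10000 nM

In a functional assay on BaF3 cells (Mus musculus) for inhibition, read by MTT assay, with a stated time of 3 days (a higher number here means a weaker inhibitor of growth, a lower number a stronger inhibitor of growth), compound 2 stands at > 10000 nM, which is a limit and not a number. The picture so far is the limit of > 10000 nM in this assay, at which 2 of the 2 values shown sit. For the measured compounds named here, the one measured step is a step that the two limits leave unreadable from compound 1 to compound 2, so it offers no size to carry forward. Compound 3 `O=C(Nc1ccc(Br)cc1)Nc1ccc(Nc2ncnc3c2OCCN3)cc1` differs from compound 2 in a single place: bromo in place of chloro on an aromatic carbon. No measured step sizes this change, so no shift beyond the scatter is expected in this assay. For compound 3 the estimate is 12000 nM, with an expected range of 4000 nM to 30000 nM.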

Compound 3, concentration for 50% growth inhibition: 10000 nM
Compound 3: middle estimate off by 1.2-fold (0.08 log units), on the high side; measured number inside the range.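

In this assay compound 3 gives 10000 nM as a number and not a limit, the only such value among the compounds shown. Compound 2 stands at > 10000 nM as a limit of the assay. The change from chloro to bromo is a number no higher from compound 2 to compound 3 (the limit leaves the size open) and this position has yet to show a measurable step: the limit of > 10000 nM in this assay, at which 2 of the 3 values shown sit.

On these data alone, what a methoxy group, an amine or a carboxylic acid would give in place of the bromo stays open. So does whether any group on this aromatic carbon gives stronger inhibition of growth.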